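The compounds below may be only part of what the source reports. "The series", "measured", "known", "first", "only" and "open" are said of these compounds alone.

Measured compounds in a functional assay on PC-3 cells (Homo sapiens) for cytotoxicity, read by MTT assay, with a stated time of 72 h; on this read-out lower numbers stand for stronger inhibition of growth and higher numbers for weaker inhibition of growth:

compound 1 `C[Se]/C(=N\C(=O)c1cc2ccccc2s1)NC(=O)c1cc2ccccc2s1`: 37200 nM
compound 2 `O=C(/N=C(/NC(=O)c1csc([N+](=O)[O-])c1)[Se]Cc1ccccc1)c1csc([N+](=O)[O-])c1`: 35900 nM
compound 3 `O=C(/N=C(/NC(=O)c1cc2ccccc2s1)[Se]Cc1ccccc1)c1cc2ccccc2s1`: 30500 nM

All three numbers sit within the scatter of one another; no order among them is claimed. Compound 1 and compound 3 share a core and differ only by hydrogen in place of phenyl on a saturated chain carbon bound to a selenium atom; this step, a 1.2-fold higher number from compound 3 to compound 1 (0.09 log units; within the scatter), is within the scatter. Compound 2 and compound 3 carry different cores; the difference between the two cores is not broken down here.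

Compound 4 `C[Se]/C(=N\C(=O)c1csc([N+](=O)[O-])c1)NC(=O)c1csc([N+](=O)[O-])c1` is not yet measured. It differs from compound 2 by hydrogen in place of phenyl on a saturated chain carbon bound to a selenium atom, the same change as from compound 3 to compound 1, at a place described in the same words. The step is expected to be a 1.2-fold higher number from compound 2 to compound 4 (0.08 log units; within the scatter), resting on the within-scatter step a 1.2-fold higher number from compound 3 to compound 1 (0.09 log units; within the scatter) and on the value of compound 2 in this assay, 35900 nM. Compound 4 is therefore estimated at 43000 nM, with a likely range from 20000 nM to 90000 nM.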

Compound 4, concentration for 50% growth inhibition: 100 nM
Compound 4: middle estimate off by 430-fold (2.63 log units), on the high side; the measured number lies below the stated range.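

In this assay, replacing benzyl with methyl, a change on a saturated chain carbon bound to a selenium atom, does not carry over from one core to the other: the same change on two cores in this assay, a 1.2-fold higher number (0.09 log units; within the scatter) from compound 3 to compound 1 and a 360-fold lower number (2.56 log units; beyond the scatter) from compound 2 to compound 4, 440-fold (2.64 log units) apart, beyond the scatter of two such steps

On the core of compound 2, the change gives a 360-fold lower number from compound 2 to compound 4 (2.56 log units; beyond the scatter), so a within-scatter result on one core gives no safe estimate for the other in this series. This comparison rests on one pair per core and does not show which difference between the cores goes with the gap.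

Still open, going by these compounds, is whether the gap persists with an ethyl group or a longer chain at this place. Also open, on these data alone, is whether a core carrying a carboxylic acid in place of the nitro group follows the core of compound 2 or that of compound 1.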